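The source may report more compounds than this note shows. Statements on the series, on what has been measured and on what is new or still open speak of the compounds shown alone.

Working notes on the series. Two compounds have been run in an ADME assay on HepG2 cells (Homo sapiens) for cytotoxicity, read by MTT assay, with a stated time of 3 days (on this read-out lower numbers stand for higher toxicity in this test and higher numbers for lower toxicity in this test), so far. Compound 1, `O=c1nc(NO)c(F)cn1[C@@H]1CS[C@H](CO)O1`, gives 855000 nM in this assay. Compound 2, `O=c1nc(NO)ccn1[C@@H]1CC(F)[C@H](CO)O1`, gives 820000 nM in this assay. These two numbers lie within the usual scatter of each other, so compound 1 stands level with compound 2 on the numbers shown, and no difference between the two can be read from them. Within the data shown here, no step between compounds differing in a single place has been worked out in this set.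

The next compound, compound 3, `O=c1nc(NO)ccn1[C@@H]1CS[C@H](CO)O1`, has not yet been run. It differs from compound 1 in one place: hydrogen in place of fluoro on an aromatic carbon. Fluoro leaves and hydrogen enters on an aromatic carbon ortho to the hydroxyamino group, two atoms from the ring nitrogen.

With both measured compounds sitting at about the same level in this assay, the expected step from compound 1 to compound 3 is a 1.0-fold lower number from compound 1 to compound 3 (0.01 log units; within the scatter), which is taken to be none beyond the scatter. The estimate for compound 3 in this assay is 830000 nM, with a range from 400000 nM to 1600000 nM.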

Compound 3, half-maximal cytotoxic concentration: 1320000 nM
Compound 3: middle estimate off by 1.6-fold (0.20 log units), on the low side; measured number inside the range.
By their numbers in this assay, from the lowest: compounds 2, 1 and 3 (each within the scatter of the next).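

Among these compounds, this is the first step that can be read at a single place: in this assay, hydrogen in place of fluoro on the aromatic carbon ortho to the hydroxyamino group gives a 1.5-fold higher number from compound 1 to compound 3 (0.19 log units; within the scatter) and so stays within the usual scatter. On this one pair, compound 1 and compound 3 therefore cannot be told apart in this test, and the fluoro at this position makes no readable difference to the read-out, whether it stands there or hydrogen does. Nothing available bears on why the pair stands level, and the result is recorded here only as an observation.

On these data alone, whether a chlorine, a methyl or an amine on this same aromatic carbon would also stay within the scatter of compound 1 remains open. Among the compounds shown here, also open is whether the same exchange of fluoro for hydrogen would read the same way on the core of compound 2, which differs from compound 3 in more than one place and so gives no step here.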